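A few compounds are considered here, and "the series" means these few. Any claim that something is new, unique, unknown or untested is made for them only; others in the source may bear on it.

Compound 1 `Cc1cccc(C(=O)OC2CCC(CN3CCN(c4cc(=O)c5cc(C(F)(F)F)cc([N+](=O)[O-])c5s4)CC3)CC2)c1`: > 64 ug/mL (a limit)
Compound 2 `CC(=O)OC1CCC(CN2CCN(c3cc(=O)c4cc(C(F)(F)F)cc([N+](=O)[O-])c4s3)CC2)CC1`: > 64 ug/mL (a limit)

In an ADME assay on Vero cells (Chlorocebus sabaeus) for cytotoxicity, read by MTT assay, with a stated time of 48 h (a lower number here means a stronger inhibitor, a higher number a weaker inhibitor), compound 2 gives > 64 ug/mL as a limit of the assay, not a number. Compound 3 `O=C(OC1CCC(CN2CCN(c3cc(=O)c4cc(C(F)(F)F)cc([N+](=O)[O-])c4s3)CC2)CC1)c1ccc2c(c1)OCC2` alters the group on the carbonyl carbon: a group of 9 heavy atoms (8 carbon, 1 oxygen; one five-membered non-aromatic ring with 1 hetero atom, one six-membered aromatic ring of carbon only) in place of one carbon atom, on a carbonyl carbon is the whole change. Among the measured compounds shown here, the one measured step that bears on this is a step that the two limits leave unreadable from compound 1 to compound 2 and its size cannot be read. Compound 1, which carries 3-methylphenyl in that place, gives > 64 ug/mL as a limit as well. The evidence so far is the limit of > 64 ug/mL in this assay, at which 2 of the 2 values shown sit, and nothing firmer. No step beyond the scatter is expected, so the estimated change is a number no higher from compound 2 to compound 3 (the limit leaves the size open) for now. The expected value for compound 3 is 64 ug/mL within an estimated range of 32 ug/mL to 128 ug/mL in this assay.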

Compound 3, half-maximal inhibitory concentration: > 64 ug/mL
Compound 3 ended at the assay's limit (the forecaster's own chance of this, stated with the estimate: 80%); the middle value sits exactly at the limit.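

Among the compounds shown here, compound 1, compound 2 and compound 3 all end at a limit in this assay and not at a number, so no step among them can be read. From the compounds shown here alone, the concentration at which any of them harms the cells remains open.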